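Series notes: chain truncation at the sulfonyl group, compound 3 to compound 4

The compounds below may be only part of what the source reports. "The series", "measured", "known", "first", "only" and "open" are said of these compounds alone.

Measured so far in an ADME assay on microsomes from liver (Rattus norvegicus) for metabolic stability, with a stated time of 10 min; a lower number here means that less of the compound is left, a higher number that more of the compound is left:
compound 1, `CC(C)(C)NC(=O)NCCS(=O)(=O)NC(=O)c1ccc(Nc2nc(NC3(c4ccc(Cl)cc4)CC3)nc(OCC(F)(F)F)n2)cc1`, gives 93%
compound 2, `CC(C)OC(=O)NCCS(=O)(=O)NC(=O)c1ccc(Nc2nc(NC3(c4ccc(Cl)cc4)CC3)nc(OCC(F)(F)F)n2)cc1`, gives 73%
compound 3, `CC(=O)NCCS(=O)(=O)NC(=O)c1ccc(Nc2nc(NC3(c4ccc(Cl)cc4)CC3)nc(OCC(F)(F)F)n2)cc1`, gives 100%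

Compound 3 has the top number of the three. The gap to compound 1, a number 7 percentage points higher from compound 1 to compound 3 (within the scatter), lies within the scatter, so compound 1 and compound 3 are not separated by this assay. The gap to compound 2, a number 27 percentage points higher from compound 2 to compound 3 (beyond the scatter), is beyond the scatter, as is a number 20 percentage points lower from compound 1 to compound 2 (beyond the scatter).

The next compound, compound 4, `CS(=O)(=O)NC(=O)c1ccc(Nc2nc(NC3(c4ccc(Cl)cc4)CC3)nc(OCC(F)(F)F)n2)cc1`, differs from compound 3 by hydrogen in place of acetamidomethyl on a saturated chain carbon bound to a sulfonyl sulfur. Among the compounds with values here, none of the measured steps touches this place: all three vary the group on the carbonyl carbon, and the largest of them is modest. Within the data shown here, the whole chain now leaves, so no step here bears directly on the change, and all three measured values sit in the upper part of the scale.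

Compound 4 is therefore expected to remain high, with a number 8 percentage points lower from compound 3 to compound 4 (within the scatter) as the expected step, which is within the scatter. The estimate for compound 4 in this assay is 92%, expected to fall between 72% and 100%.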

Compound 4, percent of the compound remaining: 85%
Compound 4: the middle estimate sits 7 percentage points above what was measured; measured number inside the range.
By their numbers in this assay, from the lowest: compound 2; then compounds 4, 1 and 3 (each within the scatter of the next, the first and the last beyond it).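

In this assay, the loss of acetamidomethyl on this saturated chain carbon bound to a sulfonyl sulfur gives a number 15 percentage points lower from compound 3 to compound 4 (beyond the scatter) and is thus a readable change, which none of the steps on the carbonyl carbon could show. The outcome of truncation depends on which chain leaves: the loss of ((isopropoxycarbonyl)amino)methyl gives a number 12 percentage points higher from compound 2 to compound 4 (beyond the scatter) as an improvement, whereas the loss of (((tert-butyl)carbamoyl)amino)methyl gives a number 8 percentage points lower from compound 1 to compound 4 (within the scatter) and leaves the two compounds unseparated. No evidence on the reason for these steps is available.

Going by these compounds, what an ethyl group on the sulfonyl sulfur would give remains open, as does the effect of a longer chain. A free amine or a carboxylic acid at the chain end is also an open case, since only amide, carbamate and urea ends appear here.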